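Pyridin-4-yl for methyl on the fused ring carbon

The compounds below may be only part of what the source reports. "The series", "measured", "known", "first", "only" and "open" are said of these compounds alone.

Measured compounds:
compound 1, `CO[C@@H]1CC=C2NN(c3cc(Cl)cc(Cl)c3)C(=O)C[C@]2(C)O1`, 19400 nM
compound 2, `CO[C@@H]1CC=C2NN(c3cc(Cl)cc(Cl)c3)C(=O)C[C@]2(c2ccncc2)O1`, 9100 nM
compound 3, `COc1cc(OC)cc(N2NC3=CC[C@@H](OC)O[C@@]3(C)CC2=O)c1`, 24300 nM

The three measured compounds were tested in a functional assay on HCT-116 cells (Homo sapiens) for inhibition, read by sulforhodamine B assay, with a stated time of 48 h; on this read-out higher numbers stand for weaker inhibition and lower numbers for stronger inhibition. Compound 1 gives 19400 nM, compound 2 gives 9100 nM and compound 3 gives 24300 nM. Compound 1 and compound 3 lie within the scatter of each other; compound 2 stands beyond the scatter from both.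

Compound 1 and compound 2 share a core and differ in one place: pyridin-4-yl in place of methyl on a saturated ring carbon. The step is a 2.1-fold lower number from compound 1 to compound 2 (0.33 log units; beyond the scatter).

The core of compound 3 is not the same as that of compound 1; the difference between the two cores is not broken down here. Compound 4, `COc1cc(OC)cc(N2NC3=CC[C@@H](OC)O[C@@]3(c3ccncc3)CC2=O)c1`, is not yet measured. It differs from compound 3 in one place: pyridin-4-yl in place of methyl on a saturated ring carbon. This is the same kind of change as from compound 1 to compound 2. Around the place, the first change is written on a six-membered non-aromatic ring with 1 oxygen, next to the ring oxygen and next to the ring atom that bears a fused ring, whereas the second is written on a six-membered non-aromatic ring with 2 nitrogen, two ring bonds and three ring bonds from the ring nitrogen.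

Compound 4 is expected to show a step of a 2.1-fold lower number from compound 3 to compound 4 (0.32 log units; beyond the scatter) from compound 3, because the same kind of change gave a 2.1-fold lower number from compound 1 to compound 2 (0.33 log units; beyond the scatter). Compound 4 is therefore estimated at 11500 nM, expected between 5000 nM and 26000 nM.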

Compound 4, half-maximal inhibitory concentration: 6500 nM
The estimate for compound 4 lay 1.8-fold (0.25 log units) above the measured number; measured number inside the range.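

In this assay, pyridin-4-yl in place of methyl on a saturated ring carbon also lowers the number on the second core, with a 3.7-fold lower number from compound 3 to compound 4 (0.57 log units; beyond the scatter). The change therefore carries over from one core to the other in direction, and the sizes of its two steps cannot be told apart: the same change on two cores in this assay, a 2.1-fold lower number (0.33 log units; beyond the scatter) from compound 1 to compound 2 and a 3.7-fold lower number (0.57 log units; beyond the scatter) from compound 3 to compound 4, 1.8-fold (0.24 log units) apart, within the scatter of two such steps. Within the data shown here, this rests on only two matched pairs in a single cell assay at one stated time, so it shows no general rule for the series and gives no reason for the shift on either core.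

Open, on these data alone, is whether the pyridine nitrogen matters for the step, which a comparison of pyridin-4-yl with plain phenyl on the same ring carbon would test, and whether pyridin-3-yl, a carboxylic acid, an amine or a longer alkyl chain at that place would move the number in the same direction. Also open is whether the step would hold on cores other than these two, and whether it would hold in cell lines other than the one shown here.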